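Working notes: one added methoxy on compound 2

The compounds below may be only part of what the source reports. "The series", "measured", "known", "first", "only" and "open" are said of these compounds alone.

Measured in a functional assay on MCF7 cells (Homo sapiens) for antiproliferative activity, read by sulforhodamine B assay, with a stated time of 48 h; on this read-out lower numbers stand for stronger inhibition and higher numbers for weaker inhibition:
- compound 1 `COc1ccc(C=C(C(=O)/C=C/c2cccc(OC)c2OC)C(=O)/C=C/c2cccc(OC)c2OC)cc1OC`: 560 nM
- compound 2 `COc1ccc(/C=C/C(=O)C(=Cc2ccc(O)c(OC)c2)C(=O)/C=C/c2ccc(OC)cc2OC)c(OC)c1`: 2140 nM

Of these two, compound 2 has the higher number and so the weaker inhibition, a gap beyond the usual scatter from compound 1. The two compounds differ in more than one place, so this gap gives no measure of any single change.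

Next is compound 3 `COc1ccc(/C=C/C(=O)C(=Cc2cc(OC)c(O)c(OC)c2)C(=O)/C=C/c2ccc(OC)cc2OC)c(OC)c1`, which differs from compound 2 by methoxy in place of hydrogen on an aromatic carbon, ortho to a hydroxy group, turning 4-hydroxy-3-methoxyphenyl into 4-hydroxy-3,5-dimethoxyphenyl. Among the compounds with values here, no measured pair shows this change, so in this assay the expectation is a small shift towards a lower number, probably none beyond the scatter. The expected size is a 1.3-fold lower number from compound 2 to compound 3 (0.13 log units; within the scatter). For compound 3 the estimated value is 1600 nM, with an expected range of 600 nM to 4200 nM.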

Compound 3, half-maximal inhibitory concentration: 970 nM
Compound 3: middle estimate off by 1.6-fold (0.22 log units), on the high side; low and high end bracket the measured number.
By their numbers in this assay, from the lowest: compounds 1 and 3 (each within the scatter of the next); then compound 2.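

In this assay, within the data shown here, methoxy in place of hydrogen on an aromatic carbon, ortho to a hydroxy group, gives a 2.2-fold lower number from compound 2 to compound 3 (0.34 log units; beyond the scatter) and is the first single change that can be read. The step is modest but beyond the scatter, so this position on the 4-hydroxy-3-methoxyphenyl ring accepts a second methoxy with no loss of inhibition, at least in this one pair. No supporting data bear on why the number falls.

On these data alone, whether the step depends on the hydroxy group remains open, since both compounds carry it and neither has a methoxy or hydrogen in its place. As far as these compounds go, it is also open how a different group at this position, such as an ethoxy, a fluorine or an amine, would compare with methoxy.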